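The source may report more compounds than this note shows. Statements on the series, on what has been measured and on what is new or still open speak of the compounds shown alone.

Three compounds have been measured in a functional assay on MCF7 cells (Homo sapiens) for cytotoxicity, read by sulforhodamine B assay, with a stated time of 48 h; on this read-out lower numbers stand for stronger inhibition of growth and higher numbers for weaker inhibition of growth:

Compound 1 `O=C1C(=O)N(CN2CCN(c3ccnc4cc(Cl)ccc34)CC2)c2cccc(Cl)c21` gives 39100 nM.
Compound 2 `O=C1C(=O)N(CN2CCN(c3ccnc4cc(Cl)ccc34)CC2)c2cccc(Br)c21` gives 15100 nM.
Compound 3 `NC(=S)N/N=C1/C(=O)N(CN2CCN(c3ccnc4cc(Cl)ccc34)CC2)c2cc(Cl)ccc21` gives 22500 nM.

Compound 1 and compound 2 share one core and differ only in bromo in place of chloro on an aromatic carbon; in this assay that change gave a 2.6-fold lower number from compound 1 to compound 2 (0.41 log units; beyond the scatter). Compound 3 has a different core; the difference between the two cores is not broken down here. Compound 4 `NC(=S)N/N=C1/C(=O)N(CN2CCN(c3ccnc4cc(Cl)ccc34)CC2)c2cc(Br)ccc21` is related to compound 3 by bromo in place of chloro on an aromatic carbon, the same kind of change as that from compound 1 to compound 2, though the place is not identical: here the carbon is meta to a fused ring and para to a fused ring, whereas before it was ortho to a fused ring and meta to a fused ring. Because a 2.6-fold lower number from compound 1 to compound 2 (0.41 log units; beyond the scatter) was modest, a step of similar size is expected for compound 4, namely a 2.0-fold lower number from compound 3 to compound 4 (0.31 log units; beyond the scatter). Compound 4 is therefore estimated at 11000 nM, with a range from 5000 nM to 30000 nM expected.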

Compound 4, concentration for 50% growth inhibition: 11400 nM
Estimate against measurement, compound 4: 1.0-fold (0.02 log units) below, and the stated range covers the measured number.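

In this assay bromo in place of chloro gives a 2.0-fold lower number from compound 3 to compound 4 (0.30 log units; within the scatter) and so, taken alone, this step cannot be told apart from the ordinary variation between repeated measurements. Going by these compounds alone, only two pairs carry this change, and the halogen sits on a different carbon in each, so nothing here shows that the step would hold on further cores. Set side by side, the two steps point the same way and do not differ in size, so the change carries over between these two cores: the same change on two cores in this assay, a 2.6-fold lower number (0.41 log units; beyond the scatter) from compound 1 to compound 2 and a 2.0-fold lower number (0.30 log units; within the scatter) from compound 3 to compound 4, 1.3-fold (0.12 log units) apart, within the scatter of two such steps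

Still open, going by these compounds, is how a fluoro, a methoxy or an amine on this aromatic carbon would compare with chloro and bromo. Also open, on these data alone, is whether the step keeps its size when the halogen moves to another carbon of the same core.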